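From an amide linker to a basic amine chain

This account rests on a few compounds, and the source may have more. Where it says the series, first, only, none or still open, it means among the compounds named here.

Within the data shown here, compound 2 `CN(C)C1CCN(C(=O)COc2cc(C(=O)N3CCCCc4sccc43)ccc2NC(=O)c2ccccc2-c2ccccc2)CC1` is the only compound here with a plain number: in a functional assay on the whole organism for antagonist activity, with Rattus norvegicus as the target (a higher number here means that more compound is needed for the effect, a lower number that less compound is needed), compound 2 gives 0.02 mg/kg. Compound 1 `CN1CCN(CCCCOc2cc(C(=O)N3CCCCc4sccc43)ccc2NC(=O)c2ccccc2-c2ccccc2)CC1` gives < 0.01 mg/kg in this assay, which is a limit of the assay rather than a number. Among the measured compounds shown here, the single measured step, an at least 2.0-fold higher number from compound 1 to compound 2 (0.30 log units; that floor lies within the scatter), is small and its true size is uncertain because of the limit of < 0.01 mg/kg in this assay, at which 1 of the 2 values shown sits. Compound 3 `CN1CCCN(CCCOc2cc(C(=O)N3CCCCc4sccc43)ccc2NC(=O)c2ccccc2-c2ccccc2)CC1` differs from compound 2 thus: 2-(4-methyl-1,4-diazepan-1-yl)ethyl in place of (4-(dimethylamino)piperidin-1-yl)carbonyl on a saturated chain carbon bound to an oxygen on an aromatic ring. Since this restores a chain-linked ring amine resembling compound 1, the step of a 2.0-fold lower number from compound 2 to compound 3 (0.30 log units; within the scatter) is expected to be a modest lowering, near the scatter. Compound 3 is estimated at 0.01 mg/kg, between 0.003 mg/kg and 0.04 mg/kg.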

Compound 3, dose for 50% inhibition: 0.03 mg/kg
Estimate against measurement, compound 3: 3.0-fold (0.48 log units) below; low and high end bracket the measured number.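

Swapping the carbonyl-linked (4-(dimethylamino)piperidin-1-yl)carbonyl for 2-(4-methyl-1,4-diazepan-1-yl)ethyl gives a 1.5-fold higher number from compound 2 to compound 3 (0.18 log units; within the scatter), so this position carries either group without a difference that stands out from the scatter. Putting 4-methyl-1,4-diazepan-1-yl in place of (4-methylpiperazin-1-yl)methyl gives an at least 3.0-fold higher number from compound 1 to compound 3 (0.47 log units; beyond the scatter), so the ring amine on the chain can matter more than the carbonyl did. The value of compound 1 is a limit and not a number, so this step is only a floor: the limit of < 0.01 mg/kg in this assay, at which 1 of the 3 values shown sits.

Going by these compounds, how an open-chain amine such as dimethylamino, or a carboxylic acid, would fare at this position remains open. So does the effect of a longer chain.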